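From phenyl to 4-nitrophenyl at the assay limit

This account rests on a few compounds, and the source may have more. Where it says the series, first, only, none or still open, it means among the compounds named here.

In a functional assay on HT-29 cells (Homo sapiens) for inhibition, read by sulforhodamine B assay, with a stated time of 48 h (a lower number here means a stronger inhibitor of growth, a higher number a weaker inhibitor of growth), compound 1 (`CCOC(=O)c1nn(-c2ccccc2)c(-c2ccc(F)cc2)c1CNC(C)(C)C`) gives 65400 nM; 29900 nM (2 entries) across its entries, and compound 2 (`CCOC(=O)c1nn(-c2ccccc2)c(-c2ccccc2)c1CNC(C)(C)C`) gives 69600 nM; 94600 nM (2 entries) across its entries. Among the compounds with values here, compound 3 (`CC(C)(C)NCc1c(C(=O)O)nn(-c2ccccc2)c1-c1ccccc1`) has no single number in this assay, since its one value shown (> 716000 nM) is a limit. Two further entries for compound 3 also carry no single number.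

Compound 4 (`CC(C)(C)NCc1c(C(=O)O)nn(-c2ccccc2)c1-c1ccc([N+](=O)[O-])cc1`) differs from compound 3 by nitro in place of hydrogen on an aromatic carbon in the structure, with nitro in place of hydrogen on an aromatic carbon, para to a large group. Within the data shown here, no measured pair in this set shows what such a change does, so the expectation rests on compound 3 alone and on the structural change. In this assay no step beyond the usual scatter is expected in either direction, and compound 4 may well return only a limit too. The expected step of an at least 1.1-fold lower number from compound 3 to compound 4 (0.04 log units; that floor lies within the scatter) is therefore small. For compound 4 an expected value of 650000 nM is estimated, with 200000 nM to 1000000 nM as its expected range.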

Compound 4, concentration for 50% growth inhibition: > 634000 nM
Compound 4: only a limit was reported; the forecaster's own chance of this, stated with the estimate: 85%; the middle value does not contradict the limit.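

In this assay compound 3 gives only a limit, > 716000 nM. Compound 4 also gives only a limit, > 634000 nM, so no step can be read between compound 3 and compound 4. The compounds shown leave open what the change from phenyl to 4-nitrophenyl does to growth inhibition.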